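A Carboxymethylphenyl Analogue Awaiting Its Cytotoxicity Reading

The source may report more compounds than this note shows. Statements on the series, on what has been measured and on what is new or still open speak of the compounds shown alone.

Compound 3 `CCOC(=O)CCCCCOc1cccc(CN(C(=O)c2ccc(-c3ccc4c(c3)OCCO4)cc2)C(C)C)c1` is known in an ADME assay on HEK293 cells (Homo sapiens) for cytotoxicity, read by CellTiter-Glo and resazurin assay, with a stated time of 72 h (a higher number here means that more compound is needed for the effect, a lower number that less compound is needed), only by a limit, > 24400 nM, which is not a number. Compound 1 `CCOC(=O)CCCCCOc1cccc(CN(C(=O)c2ccc(-c3cccnc3)cc2)C(C)C)c1` likewise returns only a limit in this assay, > 26000 nM. Compound 2 `CCOC(=O)CCCCCOc1cccc(CN(C(=O)c2ccc(-c3cccc(OCC(C)C)c3)cc2)C(C)C)c1` also ends at a limit in this assay, > 26000 nM. Every value therefore sits at an edge of the assay, as the limit of > 24400 nM in this assay, at which 1 of the 3 values shown sits, and the limit of > 26000 nM in this assay, at which 2 of the 3 values shown sit, show, and none of the steps among the three can be sized: a step that the two limits leave unreadable from compound 1 to compound 2, a step that the two limits leave unreadable from compound 1 to compound 3 and a step that the two limits leave unreadable from compound 2 to compound 3.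

Compound 4 `CCOC(=O)CCCCCOc1cccc(CN(C(=O)c2ccc(-c3cccc(CC(=O)O)c3)cc2)C(C)C)c1` differs from compound 3 by 3-(carboxymethyl)phenyl in place of 2,3-dihydro-1,4-benzodioxin-6-yl on an aromatic carbon. The three measured steps all exchange the ring at this same place and all are unreadable, so they give no direction and no size to carry over. The expectation for compound 4 in this assay is that it, too, will most likely be reported as a limit, with an estimated value of 30000 nM and a range from 12000 nM to 100000 nM. This expected step, a step that the limit leaves unreadable from compound 3 to compound 4, is intended to mean no change that the limits could reveal.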

Compound 4, half-maximal effective concentration: > 26000 nM
Compound 4 gave a limit, no number; the forecaster's own chance of this, stated with the estimate: 85%; the middle value does not contradict the limit.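

In this assay compound 4 also ends at a limit, > 26000 nM, which is not a number, so its steps from compound 1, compound 2 and compound 3 cannot be read. The compounds shown leave open whether exchanging the ring at this place changes the concentration needed for the effect, and in which direction.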